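Ring contraction on a nitrile cathepsin S inhibitor

The source may report more compounds than this note shows. Statements on the series, on what has been measured and on what is new or still open speak of the compounds shown alone.

Measured compounds:
compound 1, `COc1cccc2[nH]c(C(=O)N[C@@H](CC(C)C)C(=O)N[C@H](C=O)C[C@@H]3CCNC3=O)cc12`: 40 nM
compound 2, `COc1cccc2[nH]c(C(=O)N[C@@H](CC(C)C)C(=O)N[C@H](C#N)C[C@@H]3CCCNC3=O)cc12`: 2500 nM

Of the two compounds measured in an assay on isolated protein for inhibition of cathepsin S (Homo sapiens) (a lower number here means a stronger inhibitor, a higher number a weaker inhibitor), compound 2 stands at the higher number, giving 2500 nM, while compound 1 gives 40 nM. Going by the values given here, the single measured step, a 63-fold higher number from compound 1 to compound 2 (1.80 log units; beyond the scatter), bundles two alterations at once: the aldehyde is replaced by a nitrile and the lactam ring is enlarged. Compound 3, `COc1cccc2[nH]c(C(=O)N[C@@H](CC(C)C)C(=O)N[C@H](C#N)C[C@@H]3CCNC3=O)cc12`, keeps the nitrile of compound 2 and reverses only the ring part of that step: 2-oxopyrrolidin-3-yl in place of 2-oxopiperidin-3-yl on a saturated chain carbon, two bonds along the chain from an amide-type nitrogen and a triple-bonded carbon. The measured data do not separate how much of the step from compound 1 to compound 2 belongs to the ring and how much to the warhead, so the expectation for compound 3 can only be that it recovers some part of that loss and lands between the two measured values. Compound 3 is therefore expected to show a lower number than compound 2 in this assay, with an estimated step of an 8.3-fold lower number from compound 2 to compound 3 (0.92 log units; beyond the scatter). The estimate for compound 3 is 300 nM, within a range of 60 nM to 1500 nM.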

Compound 3, half-maximal inhibitory concentration: 700 nM
Estimate against measurement, compound 3: 2.3-fold (0.37 log units) below, and the stated range covers the measured number.
By their numbers in this assay, from the lowest: compound 1; then compound 3; then compound 2.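

With the nitrile held constant, the lactam ring alone matters in this assay: the 2-oxopyrrolidin-3-yl group in place of 2-oxopiperidin-3-yl gives a 3.6-fold lower number from compound 2 to compound 3 (0.55 log units; beyond the scatter), a modest gain that is beyond the scatter. With the 2-oxopyrrolidin-3-yl group held constant, cyano in place of formyl gives an 18-fold higher number from compound 1 to compound 3 (1.24 log units; beyond the scatter), so the bundled loss seen earlier can now be divided, and the larger share sits with the change from formyl to cyano rather than with the ring size. Nothing available here explains why either change moves the number in this way.

The compounds shown leave open whether the 2-oxopiperidin-3-yl group would carry the same penalty with formyl on the chain carbon, since the ring step has been read with cyano alone. They also leave open how this position would respond to a seven-membered lactam such as 2-oxoazepan-3-yl, or to an open-chain primary amide in place of the ring, with either cyano or formyl retained.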